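The source may hold more compounds than are shown below. What is called first, only, known or untested is meant among the compounds shown, and "the series" means these compounds.

Working notes on the series. Compound 1 (`O=S(=O)(c1ccccc1)N1CCN(c2nccc(Oc3cc(Cl)cc(Cl)c3)n2)CC1`) and compound 2 (`O=C(Nc1cccc(Cl)c1)N1CCN(c2nccc(Oc3cc(Cl)cc(Cl)c3)n2)CC1`) share a core and differ on an amine nitrogen in a ring. In a functional assay on MDA-MB-231 cells (Homo sapiens) for antiproliferative activity, read by MTT assay, with a stated time of 24 h (on this read-out lower numbers stand for stronger inhibition and higher numbers for weaker inhibition), compound 1 gives > 50000 nM, which is a limit and not a number. In this assay, going by the values given here, compound 2 gives 7900 nM, the only true number so far.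

Compound 3 (`CN1CCN(CC(=O)N2CCN(c3nccc(Oc4cc(Cl)cc(Cl)c4)n3)CC2)CC1`) keeps the shared core and changes the group on the carbonyl carbon: (4-methylpiperazin-1-yl)methyl in place of (3-chlorophenyl)amino on a carbonyl carbon. Here (4-methylpiperazin-1-yl)methyl stands in place of (3-chlorophenyl)amino, so the six-membered aromatic ring of carbon only is gone.

Among the compounds with values here, only one measured step bears on this change. That step, an at least 6.3-fold lower number from compound 1 to compound 2 (0.80 log units; beyond the scatter), introduced the (3-chlorophenyl)carbamoyl group that compound 3 gives up. It is a single step and it starts from a limit, so it sets direction better than size. A move back towards weaker inhibition in this assay is therefore expected, beyond the scatter but probably smaller than the measured step. The estimated change is a 2.5-fold higher number from compound 2 to compound 3 (0.40 log units; beyond the scatter). Compound 3 is expected at 20000 nM, with an estimated range of 7000 nM to 50000 nM.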

Compound 3, half-maximal inhibitory concentration: 24700 nM
Compound 3: middle estimate off by 1.2-fold (0.09 log units), on the low side; the range from low to high includes it.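

In this assay, going by these compounds alone, the change on a carbonyl carbon gives a 3.1-fold higher number from compound 2 to compound 3 (0.50 log units; beyond the scatter) and is the first step read between two true numbers. It shows that replacing (3-chlorophenyl)amino with (4-methylpiperazin-1-yl)methyl weakens inhibition beyond the scatter, yet compound 3 still gives a true number, even though the six-membered aromatic ring of carbon only and the hydrogen-bond donor of the leaving group are gone. Against the phenylsulfonyl group the reading is only an at least 2.0-fold lower number from compound 1 to compound 3 (0.30 log units; that floor lies within the scatter) and gives no size for the gap, because compound 1 stands at a limit: the limit of > 50000 nM in this assay, at which 1 of the 3 values shown sits.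

The step swaps a ring, a donor and the atoms joining them in one move, so the compounds shown do not say which of these carries it. A benzyl group on the carbonyl carbon would keep an aromatic ring without the amide hydrogen, and a (dimethylamino)methyl group would keep an amine without the second ring, so either would help to separate these parts.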